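The compounds below may be only part of what the source reports. "The series", "measured", "known", "first", "only" and "open" are said of these compounds alone.

Measured so far:
compound 1, `COc1cccc(S(=O)(=O)c2cnc3cc(F)ccc3c2-c2cccc(Cl)c2)c1`, 2.97 mL/min
compound 2, `O=S(=O)(c1cc(Cl)cc(Cl)c1)c1cnc2c(F)cccc2c1-c1cccc(Cl)c1`, 1.2 mL/min
compound 3, `COc1cccc(S(=O)(=O)c2cnc3cc(F)ccc3c2-c2cccc(F)c2)c1`, 3.36 mL/min

In an ADME assay on microsomes from liver (Homo sapiens) for metabolic stability, tested at 2.5 uM (a higher number here means faster removal of the compound, a lower number slower removal), compound 1 stands second highest of the three numbers; compound 3 sits within the scatter of it, while compound 2 sits beyond the scatter below it. For the measured compounds named here, the only single-place step is a 1.1-fold higher number from compound 1 to compound 3 (0.05 log units; within the scatter), a change on the aryl that is not the sulfonyl aryl, and it says little about the present change.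

Compound 4 is `COc1ccc(S(=O)(=O)c2cnc3cc(F)ccc3c2-c2cccc(Cl)c2)cc1Cl`. Change from compound 1: 3-chloro-4-methoxyphenyl in place of 3-methoxyphenyl on a sulfonyl sulfur. Going by the values given here, no measured step alters the sulfonyl aryl alone; compound 2 carries a chlorinated sulfonyl aryl and gives 1.2 mL/min, but it differs in more than one place. A small step downward, or none beyond the scatter, is expected: a 1.3-fold lower number from compound 1 to compound 4 (0.11 log units; within the scatter). Compound 4 is estimated at 2.3 mL/min, range 1.2 mL/min to 4.5 mL/min.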

Compound 4, intrinsic clearance in a liver preparation (reported as CLH), per the amount of preparation that the assay uses: 1.19 mL/min
Estimate against measurement, compound 4: 1.9-fold (0.29 log units) above; the measured number lies below the stated range.
By their numbers in this assay, from the lowest: compounds 4 and 2 (each within the scatter of the next); then compounds 1 and 3 (each within the scatter of the next).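

On the sulfonyl sulfur, 3-chloro-4-methoxyphenyl in place of 3-methoxyphenyl gives a 2.5-fold lower number from compound 1 to compound 4 (0.40 log units; beyond the scatter) in this assay. For the compounds shown here, this is the first single-place step at this position, and it shows that a change to the sulfonyl aryl alone can move the number beyond the scatter, whereas a 1.1-fold higher number from compound 1 to compound 3 (0.05 log units; within the scatter) on the other aryl does not. No measured evidence here accounts for this step.

From the compounds shown here alone, whether the chlorine or the altered placement of the methoxy carries the step stays open. Also open, going by these compounds, is how an amine or a carboxylic acid on the sulfonyl aryl would compare.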